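A few compounds are considered here, and "the series" means these few. Any claim that something is new, unique, unknown or untested is made for them only; others in the source may bear on it.

Values so far in an ADME assay on a cell-free system (plasma, Homo sapiens) for protein binding, read by LC-MS, with a stated time of 4 h, tested at 10 uM

- Compound 1 `O=C1COCCN1c1ccc(C2CC(c3ccc([N+](=O)[O-])o3)=NO2)cc1F` gives 70.8%
- Compound 2 `CN1CCN(c2ccc(C3CC(c4ccc([N+](=O)[O-])o4)=NO3)cc2F)C(=O)C1` gives 60.9%

With only these two values, compound 1 cannot be separated from compound 2, since the gap between them lies within the scatter. Compound 3 `O=C1COCCN1c1ccc(C2CC(c3ccc([N+](=O)[O-])o3)=NO2)cc1` has not been measured yet. It differs from compound 1 by a single change, hydrogen in place of fluoro on an aromatic carbon. Among the measured compounds shown here, the one measured step is a 1.3-fold higher unbound fraction from compound 1 to compound 2 (0.13 log units; within the scatter). That step puts 4-methyl-2-oxopiperazin-1-yl in place of 3-oxomorpholin-4-yl and keeps the fluoro, so no measurement tests the present change directly. For the measured compounds named here, it shows only that one other change in this small set stayed within the scatter, so no step beyond the scatter is expected here, and no direction can be firmly expected. The estimated step is a 1.1-fold higher unbound fraction from compound 1 to compound 3 (0.05 log units; within the scatter). In this assay, compound 3 is expected at 67%, with an estimated range from 50% to 80%.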

Compound 3, plasma protein binding: 64.3%
For compound 3 the middle estimate is 1.1-fold (0.03 log units) (unbound fraction) below the measured one; the range from low to high includes it.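

In this assay, hydrogen in place of fluoro on the aromatic carbon ortho to the 3-oxomorpholin-4-yl group gives a 1.2-fold higher unbound fraction from compound 1 to compound 3 (0.09 log units; within the scatter). Compounds 1 and 2 both carry the fluoro, so they could say nothing about this position; this pair tests it directly and shows that, with this group present, binding to plasma protein cannot be told apart with or without the fluoro. No independent evidence bears on this result.

On these data alone, what a chloro, a methyl or a methoxy group at the same position would do stays open. Also open, as far as these compounds go, is whether hydrogen in place of fluoro would stay within the scatter in a compound carrying the 4-methyl-2-oxopiperazin-1-yl group of compound 2.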